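The source may hold more compounds than are shown below. What is called first, only, known or untested is meant among the compounds shown, and "the series" means these compounds.

Among the compounds with values here, in a functional assay on PA-1 cells (Homo sapiens) for cytotoxicity, read by MTT assay, with a stated time of 72 h (a higher number here means a weaker inhibitor, a lower number a stronger inhibitor), compound 3 `C#CCn1cc(C(=O)N[C@@H](C)CCOC(=O)[C@H]2CCCN2C(=O)OC(C)(C)C)c(=O)c2ccc(Cl)nc21` gives 5200 nM, the only plain number among the three measured compounds. Compound 1 `C#CCn1cc(C(=O)NCCCOC(=O)[C@H]2CCCN2C(=O)OC(C)(C)C)c(=O)c2ccc(Cl)nc21` gives only a limit of the assay, > 10000 nM. Compound 2 `C#CCn1cc(C(=O)NCCCOC(=O)[C@H](C)NC(=O)OC(C)(C)C)c(=O)c2ccc(Cl)nc21` likewise gives only a limit, > 10000 nM. Compound 4 `C#CCn1cc(C(=O)N[C@@H](C)CCOC(=O)[C@H](C)NC(=O)OC(C)(C)C)c(=O)c2ccc(Cl)nc21` is compound 3 with 1-((tert-butoxycarbonyl)amino)ethyl in place of 1-(tert-butoxycarbonyl)pyrrolidin-2-yl on a carbonyl carbon. The same exchange has been made once before, yet a step that the two limits leave unreadable from compound 1 to compound 2 because the limit of > 10000 nM in this assay, at which 2 of the 3 values shown sit, hides its size. The other measured step, an at least 1.9-fold lower number from compound 1 to compound 3 (0.28 log units; that floor lies within the scatter), concerns a different change and does not bear on this one. With no readable guide, compound 4 is expected to shift little, a 1.3-fold higher number from compound 3 to compound 4 (0.13 log units; within the scatter), with a real chance that this assay again reports only a limit. The estimate for compound 4 is 7000 nM, within 2500 nM to 20000 nM.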

Compound 4, half-maximal inhibitory concentration: 4900 nM
For compound 4 the middle estimate is 1.4-fold (0.15 log units) above the measured one, within the range that was stated.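

With the methyl on the chain carbon in place, the open-chain 1-((tert-butoxycarbonyl)amino)ethyl can replace the 1-(tert-butoxycarbonyl)pyrrolidin-2-yl on the carbonyl carbon without a change beyond the scatter, a 1.1-fold lower number from compound 3 to compound 4 (0.03 log units; within the scatter). The chain methyl step also now appears with this second group, an at least 2.0-fold lower number from compound 2 to compound 4 (0.30 log units; that floor lies within the scatter). As far as these compounds go, the value of compound 2 is only a limit, so the true size of that step remains unknown.

Still open, from the compounds shown here alone, is whether a free amine or a longer chain in this place would move the number beyond the scatter.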